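The source may hold more compounds than are shown below. What is called first, only, known or untested is meant among the compounds shown, and "the series" means these compounds.

Working notes on the series.

Compound 3, `COc1ccc(-c2nc(CSCc3cccc(Cl)c3)nc3ccsc23)cn1`, is the starting point for this step. In an ADME assay on cells (Homo sapiens) for cytotoxicity, read by resazurin assay, with a stated time of 5 days (a higher number here means that more compound is tolerated, a lower number that less compound is tolerated), compound 3 gives > 50000 nM, which is a limit of the assay and not a number. The two neighbours of compound 3 stand the same way. Compound 1, `COc1ccc(-c2nc(CSc3cccc(Br)c3)nc3ccsc23)cn1`, gives > 50000 nM in this assay, a limit and not a number. Compound 2, `COc1ccc(-c2nc(CSc3cc(C)cc(C)c3)nc3ccsc23)cn1`, gives > 50000 nM in this assay, again a limit and not a number. Because (the limit of > 50000 nM in this assay, at which 3 of the 3 values shown sit), none of the three values is a read number, and the steps between them cannot be sized: a step that the two limits leave unreadable from compound 1 to compound 2, a step that the two limits leave unreadable from compound 1 to compound 3 and a step that the two limits leave unreadable from compound 2 to compound 3.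

Compound 4, `COc1ccc(-c2nc(CSc3ccc(F)cc3F)nc3ccsc23)cn1`, is not yet measured. Its difference from compound 3 is 2,4-difluorophenyl in place of 3-chlorobenzyl on a sulfur. The measured steps that change the group on the sulfur, from 3-bromophenyl to 3,5-dimethylphenyl and to 3-chlorobenzyl, all stay at the same limit, so they give no readable size in either direction. The expectation for compound 4 in this assay is therefore that the step from compound 3 is a step that the limit leaves unreadable from compound 3 to compound 4, with the result most likely reported as a limit again. Compound 4 is estimated at 70000 nM, within 35000 nM to 150000 nM.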

Compound 4, half-maximal cytotoxic concentration: > 50000 nM
Compound 4 ended at the assay's limit; the forecaster's own chance of this, stated with the estimate: 85%; the middle value lies beyond the limit too.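

In this assay compound 4 gives > 50000 nM, a limit of the assay and not a number. The steps to compound 4 from compound 1, compound 2 and compound 3 cannot be read, because all four compounds sit at one limit: the limit of > 50000 nM in this assay, at which 4 of the 4 values shown sit. The compounds shown leave open whether any group on the sulfur gives a read value in this assay.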